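The source may hold more compounds than are shown below. What is called first, only, known or untested is meant among the compounds shown, and "the series" means these compounds.

Measured compounds:
Compound 1, `COc1ccc(C(=O)/C=C/c2ccc(-c3ccccc3)cc2)c2c1C=CC(C)(C)O2`: in a functional assay on HCT-116 cells (Homo sapiens) for antiproliferative activity, read by MTT assay, with a stated time of 24 h (on this read-out lower numbers stand for stronger inhibition and higher numbers for weaker inhibition), compound 1 gives > 10000 nM, which is a limit of the assay.
Compound 2, `COc1ccc(C(=O)/C=C/c2ccc(-n3ccnc3)cc2)c2c1C=CC(C)(C)O2`: in this assay compound 2 gives > 10000 nM, again a limit.
Compound 3, `COc1ccc(C(=O)/C=C/c2ccc([N+](=O)[O-])cc2)c2c1C=CC(C)(C)O2`: in this assay compound 3 gives 8880 nM.

Within the data shown here, compound 3 therefore holds the only value in this assay that is a number; the two further values are limits. The steps of an at least 1.1-fold lower number from compound 1 to compound 3 (0.05 log units; that floor lies within the scatter) and an at least 1.1-fold lower number from compound 2 to compound 3 (0.05 log units; that floor lies within the scatter) are both readable only as floors, with no size beyond that, because of the limit of > 10000 nM in this assay, at which 2 of the 3 values shown sit. The step that the two limits leave unreadable from compound 1 to compound 2 cannot be read at all.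

Compound 4, `COc1ccc(C(=O)/C=C/c2cccc(O)c2)c2c1C=CC(C)(C)O2`, is not yet measured in this assay. It differs from compound 3 in one place: 3-hydroxyphenyl in place of 4-nitrophenyl on a double-bonded chain carbon bound to a double-bonded chain carbon. Among the measured compounds shown here, no measured step involves a hydroxyl on this ring. For the measured compounds named here, the steps that touch this position, an at least 1.1-fold lower number from compound 1 to compound 3 (0.05 log units; that floor lies within the scatter) and an at least 1.1-fold lower number from compound 2 to compound 3 (0.05 log units; that floor lies within the scatter), show only that compound 3 with the nitro gives a number while the phenyl and imidazolyl compounds sit at the limit. Exchanging the nitro for the hydroxyl is expected to return a value near or at that limit. The step of a 1.4-fold higher number from compound 3 to compound 4 (0.13 log units; within the scatter) is the expected outcome, with wide uncertainty. Compound 4 is estimated at 12000 nM, in the range 4000 nM to 35000 nM.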

Compound 4, half-maximal inhibitory concentration: > 10000 nM
Compound 4 was reported as a limit; the forecaster's own chance of this, stated with the estimate: 55%; the middle value lies beyond the limit too.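

In this assay, the change to 3-hydroxyphenyl on a double-bonded chain carbon bound to a double-bonded chain carbon gives an at least 1.1-fold higher number from compound 3 to compound 4 (0.05 log units; that floor lies within the scatter), a floor that does not separate compound 4 from compound 3 beyond the scatter. Among these compounds, the true size of this step stays unread because the new value is another limit: the limit of > 10000 nM in this assay, at which 3 of the 4 values shown sit A third group at this position, one that brings a hydrogen-bond donor and leaves the nitro behind, therefore also gives no number, and compound 3 remains the sole exception among the four compounds, the only one with a measured value rather than a limit.

Steps among compound 1, compound 2 and compound 4 cannot be read, so these three groups cannot be ranked against one another, and the nitro remains the only group here tied to a number. As far as these compounds go, it remains open whether an amine, a carboxylic acid or a methoxy group on this ring, in place of the nitro or the hydroxyl, would give a number in this assay.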